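Swapping Cyclopropyl for Isopropyl on Compound 1

The source may report more compounds than this note shows. Statements on the series, on what has been measured and on what is new or still open speak of the compounds shown alone.

Of the compounds shown here, three share a core and have been measured in an assay on HEK293 cells for positive allosteric modulation of metabotropic glutamate receptor 2 (Rattus norvegicus), read by thallium flux; on this read-out higher numbers stand for larger maximal responses and lower numbers for smaller maximal responses. Compound 1 `O=C(O)c1cc(-c2cccc(COc3ccc4c(=O)n(CC5CC5)sc4c3)c2)ccc1Cl` gives 38.4% in this assay and stands lowest of the three numbers. Compound 2 `COc1ccc(C(=O)O)cc1-c1cccc(COc2ccc3c(c2)CN(C2CCCC2)C3=O)c1` gives 79.2% and compound 3 `O=C(O)c1ccc(-c2cccc(COc3ccc4c(c3)CN(C3CCCC3)C4=O)c2)c(Cl)c1` gives 89.4% in this assay; both lie beyond the scatter above compound 1. Among the measured compounds shown here, the one single-place step measured so far is a number 10.2 percentage points higher from compound 2 to compound 3 (beyond the scatter) and it concerns the 5-carboxy-2-methoxyphenyl and 4-carboxy-2-chlorophenyl groups, a part of the molecule that the next change leaves alone.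

Compound 4 `CC(C)Cn1sc2cc(OCc3cccc(-c4ccc(Cl)c(C(=O)O)c4)c3)ccc2c1=O` differs from compound 1 in one place: isopropyl in place of cyclopropyl on a saturated chain carbon bound to an aromatic nitrogen. The cyclopropyl leaves and an isopropyl enters on a saturated chain carbon bound to an aromatic nitrogen. For the measured compounds named here, no measured step touches this position, so the measured compounds give no ground for a shift in either direction in this assay. The expected step is therefore a number 0.4 percentage points lower from compound 1 to compound 4 (within the scatter) and lies within the scatter. Compound 4 is expected to reach about 38% in this assay, with a likely range from 24% to 55%.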

Compound 4, largest response reached (reported as percent of maximum), in percent of the reference or control that the assay uses: 76.2%
Beside the measured number, compound 4's estimate is 38.2 percentage points below it, outside the stated range (above it).
By their numbers in this assay, from the lowest: compound 1; then compounds 4 and 2 (each within the scatter of the next); then compound 3.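

In this assay, replacing cyclopropyl with isopropyl on a saturated chain carbon bound to an aromatic nitrogen gives a number 37.8 percentage points higher from compound 1 to compound 4 (beyond the scatter) and shows that this position is far from silent. The two groups match in their count of 3 heavy atoms, all carbon, and in having no hydrogen-bond donors or acceptors and no net charge, yet one has a ring and the other does not, so even a change this small in outline can move the maximal response strongly. No measurement offered here accounts for the step.

Still open, going by these compounds, is whether the ring or the branching of the chain matters more here. A straight butyl chain or a cyclobutylmethyl group at this place could help separate the two, and a chain ending in an amine would test how far the position tolerates a different kind of group.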